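A few compounds are considered here, and "the series" means these few. Any claim that something is new, unique, unknown or untested is made for them only; others in the source may bear on it.

Working notes on the cytotoxicity series.

Compound 1 `Cc1ccccc1-c1nn(-c2ccc(F)cc2)cc1CNCCN1CCN(C)CC1` is measured in an ADME assay on Huh-7 cells (Homo sapiens) for cytotoxicity; on this read-out higher numbers stand for lower toxicity in this test and lower numbers for higher toxicity in this test. In this assay compound 1 gives > 20000 nM, which is a limit of the assay and not a number. Compound 3 `Cc1ccccc1-c1nn(-c2ccc(F)cc2F)cc1CNCCN(C)C` shares the core of compound 1, and in this assay compound 3 gives > 20000 nM, again a limit of the assay rather than a number. Compound 2 `CN1CCN(CCCNCc2cn(-c3ccc(C(F)(F)F)cc3)nc2-c2ccc(Cl)cc2)CC1` carries a different set of aromatic substituents, and in this assay compound 2 gives 2500 nM. Two of the three values shown thus sit at the same point, which is the limit of > 20000 nM in this assay, at which 2 of the 3 values shown sit; compound 2 is the one that falls short of it.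

Compound 4 `Cc1ccccc1-c1nn(-c2ccc(N)cc2)cc1CNCCN1CCN(C)CC1` is not yet measured. It differs from compound 1 in one place: amino in place of fluoro on an aromatic carbon. Going by the values given here, no step between measured compounds isolates this change, so there is no measured precedent for its size or direction.

Expectation: since compound 1 is known only as a limit, > 20000 nM, the step from compound 1 to compound 4 in this assay is expected to be a number no higher from compound 1 to compound 4 (the limit leaves the size open), that is, no movement beyond the scatter, with the result most likely reported again as a limit. On that basis compound 4 is estimated at 20000 nM, with a range from 5000 nM to 60000 nM.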

Compound 4, half-maximal cytotoxic concentration: > 20000 nM
Compound 4: no number, only a limit; the forecaster's own chance of this, stated with the estimate: 60%; the middle value sits exactly at the limit.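

In this assay compound 4 gives > 20000 nM as a limit of the assay and not a number. Going by these compounds alone, compound 1 is also known only as a limit, so no step between compound 1 and compound 4 can be read. The compounds shown leave open whether the change from 4-fluorophenyl to 4-aminophenyl alters cytotoxicity at all. Compound 4 joins the compounds at that ceiling: the limit of > 20000 nM in this assay, at which 3 of the 4 values shown sit.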